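From 4-methylphenyl to thiophen-2-yl on the shared core

This account rests on a few compounds, and the source may have more. Where it says the series, first, only, none or still open, it means among the compounds named here.

Going by the values given here, in a functional assay on HCT-8 cells (Homo sapiens) for cytotoxicity (on this read-out higher numbers stand for an effect only at larger amounts of compound and lower numbers for an effect already at smaller amounts), compound 1 (`COC1=C(C)C(=O)/C(=C(O)/C=C/c2ccc(C)cc2)C(=O)C1(C)C`) gives 4.1 ug/mL and compound 2 (`COC1=C(C)C(=O)/C(=C(O)/C=C/c2cccc3ccccc23)C(=O)C1(C)C`) gives 2.3 ug/mL with the two values within the scatter of each other, so compound 1 stands level with the only other measured compound. Compound 3 (`COC1=C(C)C(=O)/C(=C(O)/C=C/c2cccs2)C(=O)C1(C)C`) carries thiophen-2-yl in place of 4-methylphenyl on a double-bonded chain carbon bound to a double-bonded chain carbon. Among the compounds with values here, no measured pair isolates this exchange, and no step beyond the scatter is expected in this assay in either direction. The expected step is a 1.2-fold lower number from compound 1 to compound 3 (0.07 log units; within the scatter) and remains within the scatter. Compound 3 is estimated at 3.5 ug/mL with an expected range of 1.5 ug/mL to 8 ug/mL in this read-out.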

Compound 3, concentration for half-maximal effect: 8.6 ug/mL
The estimate for compound 3 lay 2.5-fold (0.39 log units) below the measured number, and the stated range ends below it.
By their numbers in this assay, from the lowest: compounds 2 and 1 (each within the scatter of the next); then compound 3.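

In this assay, thiophen-2-yl in place of 4-methylphenyl on a double-bonded chain carbon bound to a double-bonded chain carbon gives a 2.1-fold higher number from compound 1 to compound 3 (0.32 log units; beyond the scatter), which shows that the number responds to the group at this place. This modest step is the only one shown at this place, and it lies beyond the scatter. Nothing available explains the change. From the compounds shown here alone, whether an unsubstituted phenyl, furan-2-yl or a 4-aminophenyl at this place would move the number in the same direction remains open.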